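Trimming the sulfur substituent of compound 2

The source may hold more compounds than are shown below. What is called first, only, known or untested is meant among the compounds shown, and "the series" means these compounds.

On the shared core, compound 1 `CS(=O)(=O)C1=C(N)C(=O)c2cccnc2C1=O` carries the larger sulfur group and gives 4530 nM in a functional assay on HL-60 cells (Homo sapiens) for antiproliferative activity, read by MTT assay, with a stated time of 48 h; on this read-out higher numbers stand for weaker inhibition and lower numbers for stronger inhibition. Compound 2 `C[S+]([O-])C1=C(N)C(=O)c2cccnc2C1=O` stands lowest of the two numbers, at 1300 nM in this assay, after a 3.5-fold lower number from compound 1 to compound 2 (0.54 log units; beyond the scatter). Compound 3 `CSC1=C(N)C(=O)c2cccnc2C1=O` goes one step further in the same direction: a group of 2 heavy atoms (1 carbon, 1 sulfur; no ring) in place of a group of 3 heavy atoms (1 carbon, 1 oxygen, 1 sulfur; no ring), on a double-bonded ring carbon. Within the data shown here, only that single measured step bears on it, so the same direction is expected, though the gain may shrink or vanish within the scatter. The expected step is a 1.9-fold lower number from compound 2 to compound 3 (0.27 log units; within the scatter). Compound 3 is therefore estimated at 700 nM, within 250 nM to 2500 nM.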

Compound 3, half-maximal inhibitory concentration: 7640 nM
Beside the measured number, compound 3's estimate is 11-fold (1.04 log units) below it, outside the stated range (above it).
By their numbers in this assay, from the lowest: compound 2; then compounds 1 and 3 (each within the scatter of the next).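

In this assay the trimming does not carry on, since a 5.9-fold higher number from compound 2 to compound 3 (0.77 log units; beyond the scatter) runs against the earlier 3.5-fold lower number from compound 1 to compound 2 (0.54 log units; beyond the scatter) on this double-bonded ring carbon. Methylsulfanyl and methylsulfonyl show a 1.7-fold higher number from compound 1 to compound 3 (0.23 log units; within the scatter) and so stand level, leaving the middle group of compound 2 alone with the lowest number. Nothing given here accounts for this reversal.

Open, on these data alone, is whether the low number of compound 2 survives a longer chain on the sulfur, such as an ethyl group. Also open, as far as these compounds go, is how an amine would fare at this position.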